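The source may hold more compounds than are shown below. What is called first, only, known or untested is meant among the compounds shown, and "the series" means these compounds.

In an in vivo ADME assay on the whole organism for pharmacokinetics, with Rattus norvegicus as the target, at a dose of 5 mg/kg (on this read-out lower numbers stand for slow clearance and higher numbers for fast clearance), compound 1 (`CCC(CC)[C@@H]1C(=O)N[C@H](C2Cc3ccccc3C2)C(=O)N1[C@@H](C(=O)N1CCOCC1)c1ccc(C)nc1`) gives 23 mL/min/kg and compound 2 (`Cc1ccc([C@H](C(=O)N2CCCC2)N2C(=O)[C@@H](C3Cc4ccccc4C3)NC(=O)[C@H]2CC(C)C)cn1`) gives 33 mL/min/kg and these two values lie within the scatter of each other. Compound 3 (`CCC(CC)[C@@H]1C(=O)N[C@H](C2Cc3ccccc3C2)C(=O)N1[C@@H](C(=O)N1CCOCC1)c1ccc(C)nc1C`) carries methyl in place of hydrogen on an aromatic carbon in the form of methyl in place of hydrogen on an aromatic carbon next to the ring nitrogen, so 6-methylpyridin-3-yl becomes 2,6-dimethylpyridin-3-yl. Within the data shown here, no measured pair shows this change, and no step beyond the scatter is expected in this assay for now. The estimated step of a 1.0-fold lower number from compound 1 to compound 3 (0.02 log units; within the scatter) is small and its direction is open. For compound 3 the expected clearance is 22 mL/min/kg with 11 mL/min/kg to 42 mL/min/kg as the estimated range.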

Compound 3, clearance: 15 mL/min/kg
Estimate against measurement, compound 3: 1.5-fold (0.17 log units) above; the range from low to high includes it.
By their numbers in this assay, from the lowest: compounds 3, 1 and 2 (each within the scatter of the next, the first and the last beyond it).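

In this assay, among these compounds, the first measured pair for this change gives a 1.5-fold lower number from compound 1 to compound 3 (0.19 log units; within the scatter): on the core of compound 1, methyl in place of hydrogen on an aromatic carbon next to the ring nitrogen, ortho to a large group, leaves clearance within the scatter. Among the compounds shown here, the change from 6-methylpyridin-3-yl to 2,6-dimethylpyridin-3-yl therefore gives no step that can be read beyond the scatter. No measured data bear on the origin of this result. Open, from the compounds shown here alone, are an amine, methoxy or a longer chain on this carbon, and the same methyl on compound 2.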